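A few compounds are considered here, and "the series" means these few. Any claim that something is new, unique, unknown or untested is made for them only; others in the source may bear on it.

Working notes on the series. Among the compounds with values here, in a physicochemical assay for lipophilicity, read by HPLC, measured as octanol-water partition (a higher number here means a more lipophilic compound, a lower number a more polar compound), two compounds have numbers so far. Compound 1 (`O=C1C(N2CCCC2)=NN(c2ccccc2)CN1c1ccccc1Cl`) gives 4, and compound 2 (`CN(C)C1=NN(c2ccc(Cl)cc2)CN(c2ccccc2Cl)C1=O`) gives 4.2. These two values lie within the scatter of each other, so compound 2 stands level with compound 1 on the data at hand.

The next compound to read is compound 3 (`O=C1C(N2CCCC2)=NN(c2ccc(Cl)cc2)CN1c1ccccc1Cl`). It comes from compound 2 by one change: pyrrolidin-1-yl in place of dimethylamino on a carbon with a double bond to nitrogen. Pyrrolidin-1-yl stands in place of dimethylamino on a carbon with a double bond to nitrogen, and the 2-chlorophenyl and 4-chlorophenyl groups stay as they are.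

Within the data shown here, no measured pair differs in one place only, so no measured step can serve as a guide. The expectation rests on the structural change alone and on the level set by compound 2 at 4.2. A small upward step is expected in this assay, of a size not far beyond the scatter. The estimate amounts to an expected a number 0.30 log units higher from compound 2 to compound 3 (within the scatter). For compound 3 the estimated value is 4.5, with an expected range of 4.2 to 4.9.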

Compound 3, partition coefficient: 4.6
Compound 3: the middle estimate sits 0.10 log units below what was measured; measured number inside the range.
By their numbers in this assay, from the lowest: compounds 1 and 2 (each within the scatter of the next); then compound 3.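

In this assay pyrrolidin-1-yl in place of dimethylamino on a carbon with a double bond to nitrogen gives a number 0.40 log units higher from compound 2 to compound 3 (beyond the scatter) and so provides a one-place reading at this position, with a step that stands clear of the scatter. Compound 3 also provides a one-place reading on the aromatic side: with pyrrolidin-1-yl held constant, chloro in place of hydrogen on an aromatic carbon gives a number 0.60 log units higher from compound 1 to compound 3 (beyond the scatter) in the same assay, so each of the two changes now has a size of its own, which compound 1 and compound 2, differing in two places, could not provide. No measurement on hand accounts for either step.

Open, going by these compounds, is how the number would run with piperidin-1-yl, morpholin-4-yl or diethylamino on the same carbon, since a single pair cannot tell whether the step follows the ring, the added carbons or something else. Also open, on these data alone, is whether the chloro step would keep its size with dimethylamino on that carbon, and how fluoro or methoxy would compare with chloro on the phenyl ring.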